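This account rests on a few compounds, and the source may have more. Where it says the series, first, only, none or still open, it means among the compounds named here.

Measured compounds:
- compound 1 `CC1=CC[C@H](C(C)(C)NC(=S)NN)CC1`: in a functional assay on 786-0 cells (Homo sapiens) for inhibition, read by sulforhodamine B assay, with a stated time of 48 h (a higher number here means a weaker inhibitor of growth, a lower number a stronger inhibitor of growth), compound 1 gives only the assay limit > 100000 nM, not a number.
- compound 2 `CC1=CC[C@H](C(C)(C)NC(=S)N/N=C/c2ccccc2O)CC1`: in this assay compound 2 gives 4600 nM.
- compound 3 `CC1=CC[C@H](C(C)(C)NC(=S)N/N=C/c2ccco2)CC1`: in this assay compound 3 gives 11700 nM.

Compound 3 holds the higher of the two numbers in this assay; its nearest neighbour is compound 2, with a 2.5-fold higher number from compound 2 to compound 3 (0.41 log units; beyond the scatter). Against the limit of compound 1 the step is an at least 8.5-fold lower number from compound 1 to compound 3 (0.93 log units; beyond the scatter), which rests on (the limit of > 100000 nM in this assay, at which 1 of the 3 values shown sits).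

Compound 4 `CC1=CC[C@H](C(C)(C)NC(=S)N/N=C/c2cccs2)CC1` differs from compound 3 by thiophen-2-yl in place of furan-2-yl on a carbon with a double bond to nitrogen. Going by the values given here, the only measured step at that same position is a 2.5-fold higher number from compound 2 to compound 3 (0.41 log units; beyond the scatter), a modest change for a larger exchange of aryl group than the one here; the exchange from compound 3 to compound 4 keeps the ring size and the count of heavy atoms. In this assay the expected step is therefore small, a 1.3-fold lower number from compound 3 to compound 4 (0.11 log units; within the scatter), likely within the scatter. Compound 4 is estimated at 9000 nM, with a range of 3000 nM to 25000 nM.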

Compound 4, concentration for 50% growth inhibition: 11500 nM
Estimate against measurement, compound 4: 1.3-fold (0.11 log units) below, and the stated range covers the measured number.
By their numbers in this assay, from the lowest: compound 2; then compounds 4 and 3 (each within the scatter of the next). At a limit, above all of these: compound 1.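

In this assay, the two five-membered aromatic rings on the carbon with a double bond to nitrogen are not told apart: a 1.0-fold lower number from compound 3 to compound 4 (0.01 log units; within the scatter). The gap to the 2-hydroxyphenyl compound is therefore not peculiar to furan-2-yl, since thiophen-2-yl shows it as well: a 2.5-fold higher number from compound 2 to compound 4 (0.40 log units; beyond the scatter). Compound 1 holds a limit, not a number, so its step to the thiophen-2-yl compound reads only as a bound, an at least 8.6-fold lower number from compound 1 to compound 4 (0.93 log units; beyond the scatter), and this rests on one line of the data: the limit of > 100000 nM in this assay, at which 1 of the 4 values shown sits.

On these data alone, compound 2 differs from compound 3 and compound 4 in both the ring and the hydroxyl group, so which of the two goes with its lower number stays open. As far as these compounds go, how a plain phenyl or a 2-methoxyphenyl group would stand against compound 2 also stays open.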